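Adding a Methoxy Group on Two Related Cores

A few compounds are considered here, and "the series" means these few. Any claim that something is new, unique, unknown or untested is made for them only; others in the source may bear on it.

Compound 1 `O=c1[nH]c(/C=C/c2ccccc2)nc2ccccc12` gives 1390 nM in a functional assay on SK-N-MC cells (Homo sapiens) for cytotoxicity, read by MTT assay, with a stated time of 72 h; on this read-out lower numbers stand for stronger inhibition and higher numbers for weaker inhibition.
Compound 2 `COc1ccccc1/C=C/c1nc2ccccc2c(=O)[nH]1` gives 2880 nM in this assay.
Compound 3 `Clc1nc(/C=C/c2ccccc2)nc2ccccc12` gives 4960 nM in this assay.

Compound 4 `COc1cccc(/C=C/c2nc(Cl)c3ccccc3n2)c1` has not yet been measured. The change from compound 3 to compound 4 is methoxy in place of hydrogen on an aromatic carbon. A change of the same kind has already been measured once, from compound 1 to compound 2: methoxy in place of hydrogen on an aromatic carbon. The two are not the same change, since the surroundings differ: in compound 2 the group sits ortho to a large group, in compound 4 meta to a large group. In this assay the measured change gave a 2.1-fold higher number from compound 1 to compound 2 (0.32 log units; beyond the scatter). Compound 1 and compound 3 also carry different cores, and the difference between the two cores is not broken down here. The number for compound 3 lies beyond the usual scatter from that of compound 1, but within it from that of compound 2, so no order between compound 3 and compound 2 can be read.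

For the measured compounds named here, the only guide for compound 4 is the single earlier step, on a different core and at a different place on the ring, so the expectation is loose. The step expected here is a 1.5-fold higher number from compound 3 to compound 4 (0.18 log units; within the scatter), similar in direction to the earlier one. Compound 4 is therefore expected to give about 7500 nM in this assay, most likely between 3500 nM and 16000 nM, because the same kind of change gave a 2.1-fold higher number from compound 1 to compound 2 (0.32 log units; beyond the scatter).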

Compound 4, half-maximal inhibitory concentration: 5280 nM
Beside the measured number, compound 4's estimate is 1.4-fold (0.15 log units) above it; low and high end bracket the measured number.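

In this assay, methoxy in place of hydrogen on the aromatic carbon meta to a large group gave a 1.1-fold higher number from compound 3 to compound 4 (0.03 log units; within the scatter), so on this core the change cannot be told apart from the ordinary spread of repeated measurements. Set beside the earlier step, this result gives no sign that the change behaves differently on the two cores, although the earlier step alone lay beyond the scatter: the same change on two cores in this assay, a 2.1-fold higher number (0.32 log units; beyond the scatter) from compound 1 to compound 2 and a 1.1-fold higher number (0.03 log units; within the scatter) from compound 3 to compound 4, 1.9-fold (0.29 log units) apart, within the scatter of two such steps This does not show that the change carries over unaltered from one core to the other: there are only two steps, they differ both in core and in where the methoxy group sits on the ring, and the data cannot separate those two differences.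

The compounds shown leave open what would be seen with the methoxy group at the same place on the ring on both cores, which is the comparison that would isolate the core. They also leave open whether a different group at the place it occupies in compound 4, such as an amine, a carboxylic acid or a longer chain, would give a step beyond the scatter in this assay.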